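A Tertiary Alcohol in Place of the Lactam Ring

A few compounds are considered here, and "the series" means these few. Any claim that something is new, unique, unknown or untested is made for them only; others in the source may bear on it.

Going by the values given here, compound 1 `Cc1noc(NS(=O)(=O)c2cccc3c(N4CCCCC4=O)cccc23)c1C` gives 270 nM in an assay on VSM-A10 cells for antagonist activity at Endothelin-1 receptor (Rattus norvegicus) (a higher number here means a weaker inhibitor, a lower number a stronger inhibitor), the lower of the two numbers measured so far; compound 2 `CCOC(=O)c1c(C)noc1NS(=O)(=O)c1cccc2c(N(C)C)cccc12` gives 31000 nM in this assay, a gap that lies well beyond the usual scatter. Compound 3 `Cc1noc(NS(=O)(=O)c2cccc3c(C(C)(C)O)cccc23)c1C` carries the change (1-hydroxy-1-methylethyl in place of 2-oxopiperidin-1-yl on an aromatic carbon). Among the compounds with values here, no measured pair shares this change, so the step is expected to be small, at most a modest rise in the number and possibly none beyond the scatter. Compound 3 is therefore expected to give 450 nM, between 120 nM and 1800 nM, an expected step of a 1.7-fold higher number from compound 1 to compound 3 (0.22 log units; within the scatter).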

Compound 3, half-maximal inhibitory concentration: 2890 nM
Beside the measured number, compound 3's estimate is 6.4-fold (0.81 log units) below it; measured number above the stated range.
By their numbers in this assay, from the lowest: compound 1; then compound 3; then compound 2.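

In this assay, putting 1-hydroxy-1-methylethyl in place of 2-oxopiperidin-1-yl on this aromatic carbon brings an 11-fold higher number from compound 1 to compound 3 (1.03 log units; beyond the scatter), showing that this position responds to the group it carries. The change removes the ring and adds a hydrogen-bond donor together, so the step cannot be assigned to either alone. No measurement at hand gives a reason for the step. From the compounds shown here alone, it remains open whether a piperidine without the carbonyl would stay near compound 1, and whether an open-chain amide such as acetamide would do so.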